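The source may hold more compounds than are shown below. What is called first, only, known or untested is meant among the compounds shown, and "the series" means these compounds.

Series notes, antagonism at the free fatty acid receptor.

Compound 1 `O=S1(=O)c2ccccc2CN1c1cc(F)cc(Oc2cccnc2)c1` carries a pyridinyl ether on the shared core. In a functional assay on Flp-In T-REx293 cells for antagonist activity at Free fatty acid receptor 1 (Homo sapiens), read by calcium flux (on this read-out lower numbers stand for stronger inhibition and higher numbers for weaker inhibition), compound 1 gives only a limit, > 100000 nM, so its place among the numbers is not fixed; it sits at the limit of > 100000 nM in this assay, at which 1 of the 3 values shown sits. The two sulfonamides are open-chain relatives of the same theme: compound 2 `CCCCc1ccc(NS(=O)(=O)c2ccc(F)cc2)cc1` gives 8130 nM in this assay, and compound 3 `O=S(=O)(Nc1ccc(Oc2ccccc2)cc1)c1ccc(F)cc1` gives 12900 nM. For the measured compounds named here, the one measured step, a 1.6-fold higher number from compound 2 to compound 3 (0.20 log units; within the scatter), is the only guide to swapping a substituent on an aromatic carbon, and it carries no movement beyond the scatter.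

Compound 4 `Cc1ccccc1Oc1cc(F)cc(N2Cc3ccccc3S2(=O)=O)c1` differs from compound 1 by 2-methylphenyl in place of pyridin-3-yl on an oxygen on an aromatic ring. No measured step exchanges a heteroaryl ether for a carbocyclic one, and compound 1 is a limit, so the size of the step in this assay cannot be read from the numbers shown. The expectation for compound 4 is a number near the limit with a wide range, 40000 nM (between 8000 nM and 200000 nM). For the step from compound 1 to compound 4 the expected size is an at least 2.5-fold lower number from compound 1 to compound 4 (0.39 log units; beyond the scatter), stated with little confidence.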

Compound 4, half-maximal inhibitory concentration: 44700 nM
Estimate against measurement, compound 4: 1.1-fold (0.05 log units) below, within the range that was stated.
By their numbers in this assay, from the lowest: compounds 2 and 3 (each within the scatter of the next); then compound 4. At a limit, above all of these: compound 1.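

On the oxygen on an aromatic ring of the shared core, 2-methylphenyl in place of pyridin-3-yl gives a number rather than a limit in this assay, and the change reads as an at least 2.2-fold lower number from compound 1 to compound 4 (0.34 log units; beyond the scatter). This sets only a lower bound on the size of the step, and compound 1 remains the one limit in the set: the limit of > 100000 nM in this assay, at which 1 of the 4 values shown sits. For the compounds shown here, compound 4 differs from compound 2 and compound 3 in more than one place, and its value therefore gives no step to either open-chain sulfonamide.

Open, on these data alone, is whether the step follows the methyl group or the exchange of the ring nitrogen for carbon, a question that plain phenyl on this oxygen would address. Also open, as far as these compounds go, is how a carboxylic acid or an amine on that ring would read in this assay.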